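Chloro for Methoxy: Expected Cytotoxicity of Compound 4

The compounds below may be only part of what the source reports. "The series", "measured", "known", "first", "only" and "open" are said of these compounds alone.

Compound 1, `COc1ccccc1N1CCN(CC(=O)N2CCN(c3nnc(-c4ccccc4)c(-c4ccccc4)n3)CC2)CC1`: in an ADME assay on NIH3T3 cells (Mus musculus) for cytotoxicity, read by MTT assay, with a stated time of 24 h (on this read-out higher numbers stand for weaker inhibition and lower numbers for stronger inhibition), compound 1 gives 444000 nM.
Compound 2, `O=C(CN1CCN(c2ccccc2Cl)CC1)N1CCN(c2nnc(-c3ccccc3)c(-c3ccccc3)n2)CC1`: in this assay compound 2 gives 350000 nM.
Compound 3, `COc1ccccc1N1CCN(CC(=O)N2CCN(c3nnc(-c4ccc(C)cc4)c(-c4ccc(C)cc4)n3)CC2)CC1`: in this assay compound 3 gives 133000 nM.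

Compound 1 and compound 2 share one core and differ in a single place: chloro in place of methoxy on an aromatic carbon. In this assay this change gave a 1.3-fold lower number from compound 1 to compound 2 (0.10 log units; within the scatter), so the two numbers cannot be told apart. Compound 3 carries a different core; the difference between the two cores is not broken down here. Its number is the lowest of the three, and the gaps to compound 1 and to compound 2 are beyond the scatter.

Compound 4, `Cc1ccc(-c2nnc(N3CCN(C(=O)CN4CCN(c5ccccc5Cl)CC4)CC3)nc2-c2ccc(C)cc2)cc1`, has not yet been measured. It differs from compound 3 by chloro in place of methoxy on an aromatic carbon, the same change that separates compound 1 from compound 2, at the same kind of place. The step from compound 3 to compound 4 is therefore expected to be a 1.3-fold lower number from compound 3 to compound 4 (0.12 log units; within the scatter), beside the earlier 1.3-fold lower number from compound 1 to compound 2 (0.10 log units; within the scatter), because the shown step a 1.3-fold lower number from compound 1 to compound 2 (0.10 log units; within the scatter) stayed within the scatter. Compound 4 is expected to give about 100000 nM in this assay, estimated between 50000 nM and 200000 nM.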

Compound 4, half-maximal inhibitory concentration: > 859000 nM
Compound 4: no number, only a limit; the forecaster's own chance of this, stated with the estimate: 5%; at least 8.5-fold (0.93 log units) between middle value and limit.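

In this assay compound 4 gives no number, only a limit of the assay, > 859000 nM. On the core of compound 3, chloro in place of methoxy gave an at least 6.4-fold higher number from compound 3 to compound 4 (0.81 log units; beyond the scatter), so the near-silent result of this change on the core of compound 1 did not carry over: the same change on two cores in this assay, a 1.3-fold lower number (0.10 log units; within the scatter) from compound 1 to compound 2 and an at least 6.4-fold higher number (0.81 log units; beyond the scatter) from compound 3 to compound 4, at least 8.1-fold (0.91 log units) apart, beyond the scatter of two such steps This shows that, across these two pairs, the outcome of the change depends on the core, but it does not show which part of the core matters or why, and the full size of the step stays unknown while compound 4 has only a limit.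

Going by these compounds, it remains open whether a fluoro, a methyl or an amine at this place would behave like chloro on each of the two cores. Also open, on these data alone, is whether the change would follow the pattern of compound 3 and compound 4 on a core with ethyl or methoxy groups in place of the two methyl groups.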